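The source may hold more compounds than are shown below. What is called first, only, known or untested is meant among the compounds shown, and "the series" means these compounds.

In a functional assay on SV5A8 cells (Homo sapiens) for cytotoxicity (a lower number here means a stronger inhibitor, a higher number a weaker inhibitor), compound 1 `Cc1ccc2c(NCc3ccc(NC(=O)C4CCN(Cc5ccccc5)CC4)cc3)nc(N3CCC3)nc2c1` gives only a limit, > 8500 nM. Compound 2 `Cc1ccc2c(NCc3ccc(NC(=O)C4CCN(Cc5ccccc5)CC4)cc3)nc(N(C)CCN(C)C)nc2c1` likewise gives only a limit, > 8830 nM. Compound 3 `CCN1CCN(c2nc(NCc3ccc(NC(=O)C4CCN(Cc5ccccc5)CC4)cc3)c3ccc(C)cc3n2)CC1` gives a limit as well, > 13000 nM. On the numbers shown compound 3 thus stands at the limit of > 13000 nM in this assay, at which 1 of the 3 values shown sits, with the other two at the limit of > 8500 nM in this assay, at which 1 of the 3 values shown sits, and (the limit of > 8830 nM in this assay, at which 1 of the 3 values shown sits). The changes between them, a step that the two limits leave unreadable from compound 1 to compound 2, a step that the two limits leave unreadable from compound 1 to compound 3 and a step that the two limits leave unreadable from compound 2 to compound 3, cannot be read from such limits. Compound 4 `CCNc1nc(NCc2ccc(NC(=O)C3CCN(Cc4ccccc4)CC3)cc2)c2ccc(C)cc2n1` carries ethylamino in place of 4-ethylpiperazin-1-yl on an aromatic carbon. All three measured steps bear on this change, and all three are unreadable, so no direction or size beyond the scatter can be foreseen in this assay, and another limit is the likely outcome. For compound 4 the estimate is 12000 nM, in the range 5000 nM to 40000 nM. That estimate amounts to an expected step of an at least 1.0-fold lower number from compound 3 to compound 4 (0.03 log units; that floor lies within the scatter).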

Compound 4, half-maximal inhibitory concentration: > 2140 nM
Compound 4: only a limit was reported; the forecaster's own chance of this, stated with the estimate: 80%; the middle value lies beyond the limit too.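

Compound 4, like compounds 1, 2 and 3, gives only a limit in this assay, so none of its steps to those compounds can be read. The compounds shown leave open whether swapping the group on the aromatic carbon changes the number at all.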